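Methoxy Added Next to Hydroxyl on the Hydrazone Aryl Ring

The compounds below may be only part of what the source reports. "The series", "measured", "known", "first", "only" and "open" are said of these compounds alone.

Compound 2 `CN(C)CCn1cnnc1-c1cc(Oc2ccc(NC(=O)N/N=C/c3ccc(O)cc3)cc2F)ccn1` gives the higher of the two numbers in a functional assay on NCI-H460 cells (Homo sapiens) for cytotoxicity, read by MTT assay, with a stated time of 72 h (on this read-out lower numbers stand for stronger inhibition and higher numbers for weaker inhibition), at 1780 nM, while compound 1 `CN(C)CCn1cnnc1-c1cc(Oc2ccc(NC(=O)N/N=C/c3ccc(Cl)cc3Cl)cc2F)ccn1` gives 130 nM in this assay. Going by the values given here, the only measured step, a 14-fold higher number from compound 1 to compound 2 (1.14 log units; beyond the scatter), exchanges the whole aryl group and shows that this position matters, but it does not test a single added methoxy. Compound 3 `COc1ccc(/C=N/NC(=O)Nc2ccc(Oc3ccnc(-c4nncn4CCN(C)C)c3)c(F)c2)cc1O` differs from compound 2 by 3-hydroxy-4-methoxyphenyl in place of 4-hydroxyphenyl on a carbon with a double bond to nitrogen. Among the compounds with values here, with no directly comparable step, the expected change from compound 2 to compound 3 is a 1.2-fold lower number from compound 2 to compound 3 (0.07 log units; within the scatter), none beyond the scatter. Compound 3 is therefore estimated at 1500 nM, within a range from 500 nM to 4500 nM.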

Compound 3, half-maximal inhibitory concentration: 620 nM
Compound 3: middle estimate off by 2.4-fold (0.38 log units), on the high side, within the range that was stated.
By their numbers in this assay, from the lowest: compound 1; then compound 3; then compound 2.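

In this assay 3-hydroxy-4-methoxyphenyl in place of 4-hydroxyphenyl gives a 2.9-fold lower number from compound 2 to compound 3 (0.46 log units; beyond the scatter) and so shows that altering the substituents on this aryl ring, without exchanging it for a dichlorinated one, can move the number beyond the scatter. The gain is only partial, as a 4.8-fold higher number from compound 1 to compound 3 (0.68 log units; beyond the scatter) leaves 2,4-dichlorophenyl with the lower number. Nothing measured here explains either step. The compounds shown do not separate the contribution of the methoxy from that of the changed hydroxyl placement. They also leave open how a ring carrying only a methoxy, only one chlorine or an amine would compare.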